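Trimming Ethyl to Methyl in an Antagonist Series

The source may report more compounds than this note shows. Statements on the series, on what has been measured and on what is new or still open speak of the compounds shown alone.

Measured in a functional assay on CHO-K1 cells for antagonist activity at melanin-concentrating hormone receptor 1 (Homo sapiens), read by inositol phosphate accumulation; on this read-out higher numbers stand for weaker inhibition and lower numbers for stronger inhibition:
Compound 1 `Cc1nc(N2CCN(C3CCCC3)CC2)nc2ccc(NC(=O)COc3ccc(Cl)cc3)cc12` gives 150 nM.
Compound 2 `Cc1nc(N2CCN(C3CCOCC3)CC2)nc2ccc(NC(=O)COc3ccc(Cl)cc3)cc12` gives 115 nM.
Compound 3 `CCN1CCN(c2nc(C)c3cc(NC(=O)COc4ccc(Cl)cc4)ccc3n2)CC1` gives "not determined" (no result reported).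

Compounds 1 and 2 share one core and differ only in the group on the ring amine nitrogen; that step is a 1.3-fold lower number from compound 1 to compound 2 (0.12 log units; within the scatter). Compound 3 stands nowhere on the numbers: for it no single value exists. Compound 4 `Cc1nc(N2CCN(C)CC2)nc2ccc(NC(=O)COc3ccc(Cl)cc3)cc12` differs from compound 3 in one place, (hydrogen in place of methyl on a saturated chain carbon bound to an amine nitrogen in a ring), that is ethyl to methyl, or 4-ethylpiperazin-1-yl to 4-methylpiperazin-1-yl. For the measured compounds named here, no measured step covers an ethyl-to-methyl exchange, so the one known step gives only a rough anchor: both of its compounds carry a ring on that nitrogen and sit close together. Lacking a direct comparison, compound 4 is expected to give about 300 nM, estimated between 80 nM and 1500 nM.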

Compound 4, half-maximal inhibitory concentration: 3800 nM
The estimate for compound 4 lay 13-fold (1.10 log units) below the measured number; measured number outside the range, above it.
By their numbers in this assay, from the lowest: compounds 2 and 1 (each within the scatter of the next); then compound 4.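

In this assay the group on the amine nitrogen in a ring turns out to matter a great deal: the change to methyl gives a 33-fold higher number from compound 2 to compound 4 (1.52 log units; beyond the scatter) and a 25-fold higher number from compound 1 to compound 4 (1.40 log units; beyond the scatter) on the same core. The earlier pair showed no such gap, as its two ring-bearing compounds lie within the scatter of each other.

From the compounds shown here alone, with no value for compound 3, it stays open how ethyl compares with methyl, and what an isopropyl or benzyl group would give on that nitrogen. Nothing shown here explains the large change.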